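The source may report more compounds than this note shows. Statements on the series, on what has been measured and on what is new or still open speak of the compounds shown alone.

Compound 3 `O=C(O)Cc1sc(C(c2ccccc2)c2ccc(F)c(F)c2)nc1-c1ccc(F)cc1` carries a 3,4-difluorophenyl on a saturated chain carbon bound to two aromatic carbons; in an in vitro functional assay on HEK285-7 cells for antagonist activity at prostaglandin D2 receptor 2 (Homo sapiens), read by BRET and beta-arrestin recruitment (a higher number here means a weaker inhibitor, a lower number a stronger inhibitor), compound 3 gives 64 nM. That is the lowest of the three numbers shown, though each of the other two lies within the scatter of it. Compound 1 `O=C(O)Cc1sc(C(c2ccccc2)c2ccccc2)nc1-c1ccc(F)cc1`, with an unsubstituted phenyl at that place, gives 77 nM in this assay, and compound 2 `O=C(O)Cc1sc(C(c2ccccc2)c2ccc(Cl)cc2)nc1-c1ccc(F)cc1`, with a 4-chlorophenyl there, gives 79 nM. The steps of a 1.2-fold lower number from compound 1 to compound 3 (0.08 log units; within the scatter) and a 1.2-fold lower number from compound 2 to compound 3 (0.09 log units; within the scatter) both fall within the scatter, as does a 1.0-fold higher number from compound 1 to compound 2 (0.01 log units; within the scatter).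

Compound 4 `O=C(O)Cc1sc(C(c2ccccc2)c2ccc(O)cc2)nc1-c1ccc(F)cc1` differs from compound 3 in one place: 4-hydroxyphenyl in place of 3,4-difluorophenyl on a saturated chain carbon bound to two aromatic carbons. All three measured steps alter this same ring on this same carbon, exchanging hydrogen, chloro and fluoro, and none of them moves the number beyond the scatter. Among the compounds with values here, no measured compound carries a hydroxyl at that place, so a hydrogen-bond donor and a hydrogen-bond acceptor enter without precedent in this set. On the evidence at hand no step beyond the scatter is expected, and the estimated step of a 1.3-fold higher number from compound 3 to compound 4 (0.10 log units; within the scatter) is small. Compound 4 is therefore expected to give about 80 nM in this assay, with a range from 35 nM to 200 nM.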

Compound 4, half-maximal inhibitory concentration: 30 nM
Compound 4: middle estimate off by 2.7-fold (0.43 log units), on the high side; the measured number lies below the stated range.
By their numbers in this assay, from the lowest: compound 4; then compounds 3, 1 and 2 (each within the scatter of the next).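

Within the data shown here, at the saturated chain carbon bound to two aromatic carbons, the ring is not indifferent to what it carries: in this assay, the 4-hydroxyphenyl gives the first steps beyond the scatter, modest in size, namely a 2.1-fold lower number from compound 3 to compound 4 (0.33 log units; beyond the scatter) and a 2.6-fold lower number from compound 2 to compound 4 (0.42 log units; beyond the scatter) and a 2.6-fold lower number from compound 1 to compound 4 (0.41 log units; beyond the scatter) against the three other rings. Exchanging hydrogen, chloro and fluoro had left the number within the scatter, whereas the one ring here with a hydrogen-bond donor and a hydrogen-bond acceptor stands apart, though a single compound shows only that these two facts coincide, not that they are linked. Nothing available explains why this change lowers the number.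

As far as these compounds go, it stays open whether the lower number belongs to the hydroxy itself or would also come with a methoxy, an amine or a carboxylic acid on the same ring at that carbon. Equally open, from the compounds shown here alone, is whether a hydroxy on the second phenyl at that carbon, or at another place on the same ring, would give a step of this size.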